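A few compounds are considered here, and "the series" means these few. Any claim that something is new, unique, unknown or untested is made for them only; others in the source may bear on it.

Measured so far in a functional assay on MCF7 cells (Homo sapiens) for antiproliferative activity, read by CCK-8 assay, with a stated time of 72 h; on this read-out lower numbers stand for stronger inhibition of growth and higher numbers for weaker inhibition of growth:
- compound 1 `CCC1C(=O)N(C)c2cnc(-n3ccc4cc(C(=O)NC(C)C)ccc43)nc2N1c1ccn(C)n1` gives 8420 nM
- compound 2 `CCC1C(=O)N(C)c2cnc(-n3ccc4cc(C(=O)NC)ccc43)nc2N1c1ccn(C)n1` gives 35400 nM
- compound 3 `CCC1C(=O)N(C)c2cnc(-n3ccc4cc(F)ccc43)nc2N1c1ccn(C)n1` gives 24700 nM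

Compound 3, a fluoro analogue, is level with the methylcarbamoyl analogue within the scatter (a 1.4-fold lower number from compound 2 to compound 3 (0.16 log units; within the scatter)) but lies on the weaker side of the isopropylcarbamoyl analogue (a 2.9-fold higher number from compound 1 to compound 3 (0.47 log units; beyond the scatter)). Compound 4 `CCCNC(=O)c1ccc2c(ccn2-c2ncc3c(n2)N(c2ccn(C)n2)C(CC)C(=O)N3C)c1` has propylcarbamoyl in place of fluoro on an aromatic carbon. The size of the amide substituent alone gave a modest step (a 4.2-fold higher number from compound 1 to compound 2 (0.62 log units; beyond the scatter)). The new amide is expected to land between the methylcarbamoyl of compound 2 (35400 nM) and the isopropylcarbamoyl of compound 1 (8420 nM). A modest fall in the number is therefore expected in this assay (a 1.8-fold lower number from compound 3 to compound 4 (0.25 log units; within the scatter)). The estimate for compound 4 is 14000 nM (range 6500 nM to 30000 nM).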

Compound 4, concentration for 50% growth inhibition: 6420 nM
Beside the measured number, compound 4's estimate is 2.2-fold (0.34 log units) above it, and the stated range ends above it.
By their numbers in this assay, from the lowest: compounds 4 and 1 (each within the scatter of the next); then compounds 3 and 2 (each within the scatter of the next).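

In this assay, propylcarbamoyl on this aromatic carbon clearly improves on fluoro (a 3.8-fold lower number from compound 3 to compound 4 (0.59 log units; beyond the scatter)), which the methylcarbamoyl of compound 2 did not do, so not every amide here separates from fluoro. Going from the methyl to the propyl amide gives a step of similar size (a 5.5-fold lower number from compound 2 to compound 4 (0.74 log units; beyond the scatter)), while the propyl and isopropyl amides stay level (a 1.3-fold lower number from compound 1 to compound 4 (0.12 log units; within the scatter)), so the branch shows no readable effect. Nothing available explains these steps.

Compound 4 gives 6420 nM, and open is whether a butyl chain on the amide nitrogen, or an amine carried on the propyl chain, would take the number further down.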